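Chloro in Place of Hydrogen on Compound 2

A few compounds are considered here, and "the series" means these few. Any claim that something is new, unique, unknown or untested is made for them only; others in the source may bear on it.

Compound 1 `CC(=NNC(=S)Nc1cccc(F)c1)c1ccccn1`: 9 nM
Compound 2 `CC(=NNC(=S)Nc1ccccc1)c1ccccn1`: 0.18 nM

In a functional assay on MCF7 cells (Homo sapiens) for cytotoxicity, read by MTT assay, with a stated time of 48 h (a lower number here means a stronger inhibitor, a higher number a weaker inhibitor), compound 2 has the lower number of the two, at 0.18 nM. Compound 3 `CC(=NNC(=S)Nc1ccc(Cl)cc1)c1ccccn1` carries chloro in place of hydrogen on an aromatic carbon. For the measured compounds named here, only one measured step bears on this change: a 50-fold lower number from compound 1 to compound 2 (1.70 log units; beyond the scatter), with hydrogen in place of fluoro on an aromatic carbon, a large step beyond the scatter. Read in reverse, it points to a higher number, though chloro itself is untested and one step is thin evidence. The expected change, smaller than that measured step, is an 8.3-fold higher number from compound 2 to compound 3 (0.92 log units; beyond the scatter). Compound 3 is estimated at 1.5 nM, with an expected range from 0.15 nM to 15 nM.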

Compound 3, half-maximal inhibitory concentration: 8.5 nM
The estimate for compound 3 lay 5.7-fold (0.75 log units) below the measured number; low and high end bracket the measured number.
By their numbers in this assay, from the lowest: compound 2; then compounds 3 and 1 (each within the scatter of the next).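

In this assay, chloro on an aromatic carbon, para to a large group, gives a 47-fold higher number from compound 2 to compound 3 (1.67 log units; beyond the scatter), so this position does not tolerate the change without loss. The first halogen step, a 50-fold lower number from compound 1 to compound 2 (1.70 log units; beyond the scatter), pointed the same way, and compound 2, bare of any halogen on that ring, now has the lower number against both halogen-bearing compounds. Nothing shown gives a reason for this rise. Going by these compounds, whether a methyl group, a methoxy group or an amine on the same carbon would raise the number as well remains open, and so does whether fluoro there would match chloro.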